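The source may hold more compounds than are shown below. What is called first, only, known or untested is meant among the compounds shown, and "the series" means these compounds.

Measured so far:
compound 1 `Cc1ccccc1Nc1nc(NC2CCCCC2)ncc1Cl` — > 100000 nM
compound 2 `Cc1ccc(CNc2nc(Nc3ccc(N4CCN(C)CC4)cn3)ncc2Cl)cc1` — 18600 nM

Compound 1 reaches only a limit of the assay, (the limit of > 100000 nM in this assay, at which 1 of the 2 values shown sits). Among the measured compounds shown here, compound 2 is the only compound with a number in a functional assay on MDA-MB-231 cells (Homo sapiens) for inhibition, read by CCK-8 assay, with a stated time of 48 h (on this read-out higher numbers stand for weaker inhibition of growth and lower numbers for stronger inhibition of growth), so its standing rests on one value. Compound 3 `Cc1cc(C)c(Nc2nc(Nc3ccc(N4CCN(C)CC4)cn3)ncc2Cl)c(C)c1` carries 2,4,6-trimethylphenyl in place of 4-methylbenzyl on a nitrogen on an aromatic ring. No measured step of this kind exists among the shown compounds, so the size and direction of the change from compound 2 is open. A modest loss, beyond the scatter, is expected, a 2.2-fold higher number from compound 2 to compound 3 (0.33 log units; beyond the scatter). For compound 3 the expected value in this assay is 40000 nM, within 8000 nM to 200000 nM.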

Compound 3, concentration for 50% growth inhibition: 21000 nM
For compound 3 the middle estimate is 1.9-fold (0.28 log units) above the measured one; measured number inside the range.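

In this assay, among the compounds shown here, the first readable step at this position, 2,4,6-trimethylphenyl in place of 4-methylbenzyl on a nitrogen on an aromatic ring, gives a 1.1-fold higher number from compound 2 to compound 3 (0.05 log units; within the scatter). The assay therefore does not separate these two groups, despite the different link of the aromatic ring to the nitrogen. No measured property on hand bears on this result. This single pair leaves open whether any group at this nitrogen moves the number beyond the scatter. A longer chain ending in an amine or a carboxylic acid would test that.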